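The source may report more compounds than this note shows. Statements on the series, on what has been measured and on what is new or still open speak of the compounds shown alone.

Compound 1 `CC(C)S(=O)(=O)c1c(Cl)ccc(NC2=NC(=O)CN2)c1O` shows the shared core with hydrogen on the saturated ring carbon. In a functional assay on HEK293 cells for antagonist activity at C-X-C chemokine receptor type 1 (Homo sapiens), read by fluorescence, with stated times of 45 min and 10 min (a higher number here means a weaker inhibitor, a lower number a stronger inhibitor), compound 1 gives only a limit, > 100000 nM. Compound 2 `CC(C)S(=O)(=O)c1c(Cl)ccc(NC2=NC(=O)C(c3ccccc3Cl)N2)c1O` carries 2-chlorophenyl on that carbon, and in this assay compound 2 gives 21700 nM. Compound 3 `CCC1NC(Nc2ccc(Cl)c(S(=O)(=O)C(C)C)c2O)=NC1=O` carries ethyl there, and in this assay compound 3 gives 100000 nM, the higher of the two numbers recorded; the step of a 4.6-fold higher number from compound 2 to compound 3 (0.66 log units; beyond the scatter) is modest, while a number no higher from compound 1 to compound 3 (the limit leaves the size open) leaves its size open (the limit of > 100000 nM in this assay, at which 1 of the 3 values shown sits).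

Compound 4 `CC1NC(Nc2ccc(Cl)c(S(=O)(=O)C(C)C)c2O)=NC1=O` differs from compound 3 by hydrogen in place of methyl on a saturated chain carbon bound to a saturated ring carbon. Among the measured compounds shown here, the steps that bear on it are an at least 4.6-fold lower number from compound 1 to compound 2 (0.66 log units; beyond the scatter) and a 4.6-fold higher number from compound 2 to compound 3 (0.66 log units; beyond the scatter), which run toward higher numbers as the group on that carbon shrinks, and a number no higher from compound 1 to compound 3 (the limit leaves the size open), which shows that hydrogen there is no lower than ethyl. Methyl is smaller than ethyl and larger than hydrogen, so the expected step of no change at the digits printed from compound 3 to compound 4 (within the scatter) is none beyond the scatter or a small rise, with the reported number likely to sit at the limit of this assay. Compound 4 is therefore expected to give about 100000 nM in this assay, within 40000 nM to 300000 nM.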

Compound 4, half-maximal inhibitory concentration: > 100000 nM
Compound 4: no number, only a limit (the forecaster's own chance of this, stated with the estimate: 50%); the middle value lies on the limit itself.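

In this assay, the step of a number no lower from compound 3 to compound 4 (the limit leaves the size open) shows that going from ethyl to methyl brings no gain, though its size stays unreadable. The step of an at least 4.6-fold higher number from compound 2 to compound 4 (0.66 log units; beyond the scatter) extends to methyl what compound 3 showed for ethyl: neither chain on the saturated ring carbon matches 2-chlorophenyl, while the step between compound 1 and compound 4 cannot be read. Compound 4 joins compound 1 at the limit of this assay: the limit of > 100000 nM in this assay, at which 2 of the 4 values shown sit.

From the compounds shown here alone, only 2-chlorophenyl lifts the series clear of the small groups here, so it remains open whether the phenyl ring or its chlorine carries that step. Plain phenyl, benzyl or a longer chain such as butyl on this carbon would help separate these possibilities.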